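Swapping the Sulfonyl Aryl Group in a Serotonin Antagonist Series

This account rests on a few compounds, and the source may have more. Where it says the series, first, only, none or still open, it means among the compounds named here.

Compound 3 `CN1CCC(N(C)C(=O)C2CN(S(=O)(=O)c3cccc4c(Cl)cccc34)c3ccccc32)CC1` gives 5.01 nM in a functional assay on CHO cells for antagonist activity at 5-hydroxytryptamine receptor 6 (Homo sapiens), read by FLIPR (a lower number here means a stronger inhibitor, a higher number a weaker inhibitor), the lowest number among the three compounds measured. Compound 2 `COc1ccc(S(=O)(=O)N2CC(C(=O)N3CCNCC3)c3ccccc32)c2ccccc12` gives 7.94 nM, which lies within the scatter of compound 3, so no order between the two can be claimed. Compound 1 `COc1ccc(S(=O)(=O)N2CC(C(=O)N3CC(N)C3)c3ccccc32)c2ccccc12` gives 158 nM, a larger number beyond the scatter. Among the compounds with values here, the only single change measured so far, a 20-fold lower number from compound 1 to compound 2 (1.30 log units; beyond the scatter), sits on the carbonyl carbon and says nothing about the sulfonyl sulfur. Compound 4 `COc1cc(C)c(S(=O)(=O)N2CC(C(=O)N(C)C3CCN(C)CC3)c3ccccc32)c(C)c1C` differs from compound 3 exactly there: 4-methoxy-2,3,6-trimethylphenyl in place of 5-chloronaphthalen-1-yl on a sulfonyl sulfur. Within the data shown here, no measured step bears on this change, so the expectation rests on compound 3 alone. The step expected in this assay is a 2.0-fold higher number from compound 3 to compound 4 (0.30 log units; within the scatter), at most a modest weakening. Compound 4 is estimated at 10 nM, within a range from 3 nM to 40 nM.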

Compound 4, inhibition constant: 100 nM
Beside the measured number, compound 4's estimate is 10-fold (1.00 log units) below it; the whole stated range lies below it.
By their numbers in this assay, from the lowest: compounds 3 and 2 (each within the scatter of the next); then compounds 4 and 1 (each within the scatter of the next).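

In this assay, exchanging 5-chloronaphthalen-1-yl for 4-methoxy-2,3,6-trimethylphenyl on the sulfonyl sulfur gives a 20-fold higher number from compound 3 to compound 4 (1.30 log units; beyond the scatter), so this position matters as well as the carbonyl carbon. The two groups have equal heavy-atom counts, so that count does not separate them; they differ in having two aromatic rings or one, and in carrying chlorine or oxygen. Nothing available explains the step.

From the compounds shown here alone, whether the second ring or the chlorine matters more stays open, and plain naphthalen-1-yl on the sulfonyl sulfur would help separate them. Whether the step holds with piperazin-1-yl on the carbonyl carbon is also unknown.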